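The source may hold more compounds than are shown below. What is called first, only, known or untested is meant among the compounds shown, and "the series" means these compounds.

Compound 1 `c1ccc(Cn2ccc3nc(-c4ccccc4)nc-3c2)cc1` sets the reference point. In an ADME assay on MDBK cells (Bos taurus) for cytotoxicity (on this read-out higher numbers stand for lower toxicity in this test and lower numbers for higher toxicity in this test), compound 1 gives > 100000 nM, which is a limit of the assay rather than a number. Compound 2 `Brc1ccccc1Cn1ccc2nc(-c3ccccc3)nc-2c1` also returns a limit in this assay, namely > 100000 nM. Compound 3 `FC(F)(F)c1cccc(Cn2ccc3nc(-c4ccccc4)nc-3c2)c1` gives 98000 nM in this assay. The step that the two limits leave unreadable from compound 1 to compound 2 cannot be read, while the step of an at least 1.0-fold lower number from compound 1 to compound 3 (0.00 log units; that floor lies within the scatter) stays within the scatter. Both closed steps attach a group to the same aromatic carbon, as does the unmeasured compound 4 `FC(F)(F)Oc1ccc(Cn2ccc3nc(-c4ccccc4)nc-3c2)cc1`, where the change is trifluoromethoxy in place of hydrogen on an aromatic carbon. Given (the limit of > 100000 nM in this assay, at which 2 of the 3 values shown sit), no step beyond the scatter is expected here, and compound 4 is estimated at 100000 nM, between 50000 nM and 200000 nM, most likely reported again as a limit.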

Compound 4, half-maximal cytotoxic concentration: 66000 nM
Estimate against measurement, compound 4: 1.5-fold (0.18 log units) above; the range from low to high includes it.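

In this assay, trifluoromethoxy on this aromatic carbon, para to a large group, gives a measured number rather than a limit, and the step is an at least 1.5-fold lower number from compound 1 to compound 4 (0.18 log units; that floor lies within the scatter). So this change, the first here to bring in oxygen, shows no shift beyond the scatter. Its true size stays hidden because many readings stop at one ceiling: the limit of > 100000 nM in this assay, at which 2 of the 4 values shown sit.

From the compounds shown here alone, whether an amine or a carboxylic acid on this carbon would bring the number clearly lower stays open. Going by these compounds, how far compound 1 lies past its limit also stays open.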